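Swapping the benzyl group among compounds at the assay limit

The compounds below may be only part of what the source reports. "The series", "measured", "known", "first", "only" and "open" are said of these compounds alone.

Measured so far in a functional assay on MCF cells (Homo sapiens) for antiproliferative activity, with a stated time of 72 h (a lower number here means a stronger inhibitor, a higher number a weaker inhibitor), are three compounds, each reported only as a limit:
- Compound 1 `OC[C@H]1O[C@@H](n2cnc3c(NCc4ccc(Br)cc4)ncnc32)[C@H](O)[C@@H]1O` gives > 166000 nM as a limit
- Compound 2 `Cc1cccc(CNc2ncnc3c2ncn3[C@@H]2O[C@H](CO)[C@@H](O)[C@H]2O)c1` gives > 166000 nM as a limit
- Compound 3 `COc1ccccc1CNc1ncnc2c1ncn2[C@@H]1O[C@H](CO)[C@@H](O)[C@H]1O` gives > 166000 nM as a limit

Compound 3 therefore offers no exact number to start from. It stands with the other two compounds, and the record so far reads the limit of > 166000 nM in this assay, at which 3 of the 3 values shown sit, for the whole set.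

Moving to compound 4 `OC[C@H]1O[C@@H](n2cnc3c(NCc4ccc(Cl)cc4Cl)ncnc32)[C@H](O)[C@@H]1O` brings the change 2,4-dichlorophenyl in place of 2-methoxyphenyl on a saturated chain carbon bound to a nitrogen on an aromatic ring in which 2,4-dichlorophenyl takes the place of 2-methoxyphenyl on a saturated chain carbon bound to a nitrogen on an aromatic ring.

The measured swaps at this same place are a step that the two limits leave unreadable from compound 1 to compound 3 and a step that the two limits leave unreadable from compound 2 to compound 3 and a step that the two limits leave unreadable from compound 1 to compound 2 and none of them has a size that can be carried over. For the measured compounds named here, they point in no direction, so no step of readable size can be forecast from them.

Going by the values given here, a reading close to the limit is expected for compound 4 because the limit of > 166000 nM in this assay, at which 3 of the 3 values shown sit, holds for every compound tested so far. The expected change is a number no higher from compound 3 to compound 4 (the limit leaves the size open) and this remains only an estimate. Compound 4 is estimated at 166000 nM within an expected range of 60000 nM to 300000 nM in this assay as a cautious forecast.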

Compound 4, half-maximal inhibitory concentration: 127000 nM
For compound 4 the middle estimate is 1.3-fold (0.12 log units) above the measured one, within the range that was stated.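

For the compounds shown here, at this place, on a saturated chain carbon bound to a nitrogen on an aromatic ring, 2,4-dichlorophenyl gives the only exact reading in this assay, while the other three compounds remain at the assay limit: the limit of > 166000 nM in this assay, at which 3 of the 4 values shown sit. Against those limits, the swap to this group reads as an at least 1.3-fold lower number from compound 3 to compound 4 (0.11 log units; that floor lies within the scatter), as an at least 1.3-fold lower number from compound 2 to compound 4 (0.11 log units; that floor lies within the scatter) and as an at least 1.3-fold lower number from compound 1 to compound 4 (0.11 log units; that floor lies within the scatter). Each of these steps is only a floor, so the true size of the change stays unknown, and the compounds shown do not establish that 2,4-dichlorophenyl differs from the other rings by more than ordinary repeat variation.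

Going by these compounds, the steps among compound 1, compound 2 and compound 3 cannot be read, so how those three rings rank against one another remains unknown. Also open, on these data alone, is whether a ring carrying an amine or a carboxylic acid, or a longer chain between the ring and the nitrogen, would give a number well clear of the limit.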